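Chloro on the phenylcarbamoyl group of compound 1

The source may report more compounds than this note shows. Statements on the series, on what has been measured and on what is new or still open speak of the compounds shown alone.

In a functional assay on QGY cells (Homo sapiens) for cytotoxicity, read by MTT assay, with a stated time of 48 h (on this read-out higher numbers stand for weaker inhibition and lower numbers for stronger inhibition), compound 1 (`CCOC(=O)[C@@]1(C(=O)Nc2ccccc2)C[C@@H]1c1cc(OC)c(OC)c(OC)c1`) gives > 100000 nM, which is a limit of the assay and not a number. A further entry for compound 1 also carries no single number. Compound 3 (`CCOC(=O)[C@@]1(C(=O)Nc2ccccc2Cl)C[C@@H]1c1cc(OC)c(OC)c(OC)c1`) turns phenyl into 2-chlorophenyl, with chloro in place of hydrogen on an aromatic carbon, ortho to a large group: chloro in place of hydrogen on an aromatic carbon. For the measured compounds named here, no measured single-place step is available to size this change. The nearest guide is compound 2 (`CCOC(=O)C1(C(=O)Nc2ccccc2Cl)CC1c1cc(OC)c(OC)c(OC)c1`), which has the same 2-chlorophenyl group but no stereochemistry drawn, and compound 2 gives 36100 nM; 48800 nM (2 entries) in this assay. On that basis, a modest step towards stronger inhibition is expected in this assay, though compound 3 could still reach the limit. The expected change is an at least 2.5-fold lower number from compound 1 to compound 3 (0.39 log units; beyond the scatter). For compound 3 the estimated value is 40000 nM, with an expected range of 15000 nM to 100000 nM.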

Compound 3, half-maximal inhibitory concentration: > 100000 nM
Compound 3: a limit, no number; the forecaster's own chance of this, stated with the estimate: 25%; middle value at least 2.5-fold (0.39 log units) away from the limit.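

In this assay, for the compounds shown here, compound 3 gives > 100000 nM, a limit and not a number, as compound 1 does, so no step from compound 1 to compound 3 can be read. Still open, from the compounds shown here alone, is whether chloro in place of hydrogen changes inhibition at all, and how compound 2 relates to compound 3: the fact that one of compounds 2 and 3 is drawn with a defined configuration and the other without, at the place where they differ.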